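Swapping Nitro for Fluoro on Two Different Cores

This account rests on a few compounds, and the source may have more. Where it says the series, first, only, none or still open, it means among the compounds named here.

Compound 1 `O=[N+]([O-])c1ccc(-c2csc(N/N=C\c3ccco3)n2)cc1` and compound 3 `Fc1ccc(-c2csc(N/N=C\c3ccco3)n2)cc1` share one core and differ in one place: fluoro in place of nitro on an aromatic carbon. In an in vitro assay on BTI-TN-5B1-4 cells for inhibition of Amine oxidase [flavin-containing] A (Homo sapiens), read by Amplex Red, with a stated time of 15 min, tested at 100 uM (on this read-out lower numbers stand for less inhibition and higher numbers for more inhibition at the one concentration tested (going by the name of the read-out)), compound 1 gives 40%, and compound 3 gives 40%. The step of no change at the digits printed from compound 1 to compound 3 (within the scatter) shows that this swap left the read-out essentially where it was.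

Compound 2 `C/C(=C/CC1=CC(c2ccc([N+](=O)[O-])cc2)=CC1)c1ccc2ccccc2c1` is built on a second core; how the two cores differ is not broken down here. In this assay compound 2 is reported as "not active" (no number reported), so no number stands beside it. Compound 4 `C/C(=C/CC1=CC(c2ccc(F)cc2)=CC1)c1ccc2ccccc2c1` has not yet been measured and differs from compound 2 in exactly the same way: fluoro in place of nitro on an aromatic carbon. The place described for this change is the same in both pairs, so it is the same change.

Because the step of no change at the digits printed from compound 1 to compound 3 (within the scatter) is within the scatter, the same swap is expected to move compound 4 little from where compound 2 stands, which means weak inhibition. Compound 4 is therefore estimated to give 5% in this assay, within a range from -10% to 25%, with a real chance that the assay again reports no number.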

Compound 4, a percentage reported as inhibition, at one concentration (the size of the read-out at that concentration, not a potency): 40%
For compound 4 the middle estimate is 35 percentage points below the measured one; the whole stated range lies below it.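

In this assay, within the data shown here, compound 2 stands as "not active" (no number reported) and so no step from it to compound 4 can be read. The compounds shown leave open how far the change from 4-nitrophenyl to 4-fluorophenyl moves inhibition on the core of compound 2. No measurement at hand accounts for the result in compound 4.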